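Methyl on the ring amine of compound 2

This account rests on a few compounds, and the source may have more. Where it says the series, first, only, none or still open, it means among the compounds named here.

Measured in an ADME assay on microsomes from liver (Homo sapiens) for metabolic stability; on this read-out lower numbers stand for slow clearance and higher numbers for fast clearance:
- compound 1 `O=C(N[C@H]1CN(S(=O)(=O)c2ccccc2)C[C@@H]1C(=O)N[C@H]1CCCNC1)c1cn(C2CC2)cn1`: < 3 mL.min-1.g-1 (a limit)
- compound 2 `O=C(N[C@H]1CN(S(=O)(=O)c2ccccc2)C[C@@H]1C(=O)N[C@H]1CCCNC1)c1cc(-c2ccccc2Cl)on1`: < 3 mL.min-1.g-1 (a limit)
- compound 3 `CN(C(=O)c1cc(-c2ccccc2Cl)on1)[C@H]1CN(S(=O)(=O)c2ccccc2)C[C@@H]1C(=O)N[C@H]1CCCNC1`: 13 mL.min-1.g-1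

Compound 2 sits at the limit of < 3 mL.min-1.g-1 in this assay, at which 2 of the 3 values shown sit. Compound 4 `CN1CCC[C@H](NC(=O)[C@H]2CN(S(=O)(=O)c3ccccc3)C[C@@H]2NC(=O)c2cc(-c3ccccc3Cl)on2)C1` differs from it by methyl in place of hydrogen on an amine nitrogen in a ring. For the measured compounds named here, the one measured methyl step is an at least 4.3-fold higher number from compound 2 to compound 3 (0.63 log units; beyond the scatter), which places the methyl on an amide-type nitrogen instead. Going by the values given here, that step is the only guide, and as the site differs, a rise of similar direction but smaller size is expected in this assay. The estimated step is an at least 2.0-fold higher number from compound 2 to compound 4 (0.30 log units; that floor lies within the scatter). For compound 4 the expected value is 6 mL.min-1.g-1, with an estimated range of 2 mL.min-1.g-1 to 18 mL.min-1.g-1.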

Compound 4, intrinsic clearance in microsomes: 106 mL.min-1.g-1
For compound 4 the middle estimate is 18-fold (1.25 log units) below the measured one; the whole stated range lies below it.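

In this assay, methyl on the amine nitrogen in the ring gives an at least 35-fold higher number from compound 2 to compound 4 (1.54 log units; beyond the scatter), so this single added carbon on the piperidin-3-yl group moves clearance by a large step. The earlier compounds shown here showed a methyl step only on an amide-type nitrogen, with an at least 4.3-fold higher number from compound 2 to compound 3 (0.63 log units; beyond the scatter). Both steps start from a limit, that of compound 2: the limit of < 3 mL.min-1.g-1 in this assay, at which 2 of the 4 values shown sit.

Still open, on these data alone, is whether an ethyl or an acetyl on this ring nitrogen gives a rise of like size. Also open, as far as these compounds go, is whether the same methyl on compound 1 does so.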